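Trifluoropropyl for Isopropyl: Cytotoxicity Outlook for Compound 3

The source may report more compounds than this note shows. Statements on the series, on what has been measured and on what is new or still open speak of the compounds shown alone.

Measured compounds:
Compound 1, `CCOc1ccc2nc(-c3c(Cl)nc(N)nc3N[C@@H]3C[C@H](CO)[C@@H](O)[C@H]3O)sc2c1`: > 25000 nM
Compound 2, `Cc1nc(NC(C)C)nc(N[C@@H]2C[C@H](CO)[C@@H](O)[C@H]2O)c1-c1nc2ccccc2s1`: 13000 nM

Of the compounds shown here, two have been measured in an ADME assay on cells (Homo sapiens) for cytotoxicity, read by polymerase chain reaction, with a stated time of 3 days; a higher number here means that more compound is tolerated, a lower number that less compound is tolerated. For compound 1 the result is a limit, (the limit of > 25000 nM in this assay, at which 1 of the 2 values shown sits), and not a number. For the measured compounds named here, compound 2 therefore provides the only number in this assay, 13000 nM, so nothing has yet been measured about how any single structural change moves this read-out.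

Compound 3, `Cc1nc(NCCC(F)(F)F)nc(N[C@@H]2C[C@H](CO)[C@@H](O)[C@H]2O)c1-c1nc2ccccc2s1`, remains to be measured. It differs from compound 2 in one place: 3,3,3-trifluoropropyl in place of isopropyl on a nitrogen on an aromatic ring. Going by the values given here, with no measured step to lean on, the expectation is that the change from compound 2 to compound 3 brings a step of no more than the usual scatter in this assay, in either direction, written here as a 1.2-fold higher number from compound 2 to compound 3 (0.06 log units; within the scatter).

On that basis compound 3 is estimated at 15000 nM in this assay, with a range from 6000 nM to 40000 nM.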

Compound 3, half-maximal cytotoxic concentration: 9000 nM
Estimate against measurement, compound 3: 1.7-fold (0.22 log units) above, and the stated range covers the measured number.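

For the compounds shown here, the exchange at this position gives the first step that can be read in this assay: a 1.4-fold lower number from compound 2 to compound 3 (0.16 log units; within the scatter). At this place, on a nitrogen on an aromatic ring, the read-out of this assay therefore does not separate the 3,3,3-trifluoropropyl group from the isopropyl group, even though the entering group brings in three fluorine atoms and a larger heavy-atom count. Nothing shown here speaks to a cause of this small step.

As far as these compounds go, this is one step at one position, so it remains open whether a longer chain, a cyclopropyl group or a chain ending in a carboxylic acid on the same nitrogen would move the number beyond the scatter. From the compounds shown here alone, it also remains open whether the same exchange would behave alike on the core of compound 1.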